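The source may report more compounds than this note shows. Statements on the series, on what has been measured and on what is new or still open speak of the compounds shown alone.

In a functional assay on HeLa cells (Homo sapiens) for inhibition, read by MTT assay, with a stated time of 48 h (a lower number here means a stronger inhibitor of growth, a higher number a weaker inhibitor of growth), compound 3 `Cn1cc(C2CC(c3ccccc3)=NN2C(=O)c2cccnc2)c2cc(Br)ccc21` gives 1730 nM. Compound 2 `COc1cc(C2=NN(C(=O)c3ccc(C)nc3)C(c3cn(C)c4ccccc34)C2)cc(OC)c1OC` gives 210 nM, so compound 3 holds the higher of the two numbers. Compound 1 `Cn1cc(C2CC(c3ccccc3)=NN2C(=O)c2cccnc2)c2ccccc21` gives > 10000 nM, which is a limit of the assay.

Compound 4 `Cn1cc(C2CC(c3ccc(Br)cc3)=NN2C(=O)c2cccnc2)c2cc(Br)ccc21` adds a second bromine to compound 3: bromo in place of hydrogen on an aromatic carbon. In words, phenyl becomes 4-bromophenyl, with bromo in place of hydrogen on an aromatic carbon, para to a large group.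

Within the data shown here, one measured step bears on this: an at least 5.7-fold lower number from compound 1 to compound 3 (0.76 log units; beyond the scatter). From the compounds shown here alone, it is the same kind of replacement, made at another place in the molecule, and it starts from a limit, so its full size is unknown. On that single precedent, a modest further fall in this assay is expected, smaller than the gap to compound 2 and uncertain in size because the position differs.

The expected change is a 1.6-fold lower number from compound 3 to compound 4 (0.20 log units; within the scatter). For compound 4 the estimated value is 1100 nM, with an expected range of 350 nM to 4000 nM.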

Compound 4, concentration for 50% growth inhibition: > 10000 nM
Compound 4 was reported as a limit (the forecaster's own chance of this, stated with the estimate: 8%); at least 9.0-fold (0.95 log units) between middle value and limit.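

In this assay the same replacement gives opposite results at two places in the molecule: an at least 5.7-fold lower number from compound 1 to compound 3 (0.76 log units; beyond the scatter) at the first place, and an at least 5.7-fold higher number from compound 3 to compound 4 (0.76 log units; beyond the scatter) where phenyl becomes 4-bromophenyl. The gain seen with bromo at the first place therefore does not carry over to this position, para to a large group, and in this pair hydrogen is the better of the two substituents. Compound 4 stands at a limit, as does compound 1, so the full size of neither step can be read and the two compounds cannot be ordered: the limit of > 10000 nM in this assay, at which 2 of the 4 values shown sit.

From the compounds shown here alone, whether the loss belongs to bromo alone or to any replacement of hydrogen here stays open, and a fluoro group or an amine at this position would separate the two readings. Compound 2 differs from compound 3 in more than one place, so it does not settle the question.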